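Urea aryl variation between compound 2 and compound 4

The source may hold more compounds than are shown below. What is called first, only, known or untested is meant among the compounds shown, and "the series" means these compounds.

Measured so far in a functional assay on MDA-MB-231 cells (Homo sapiens) for cytotoxicity, read by MTT assay, with a stated time of 48 h; on this read-out higher numbers stand for weaker inhibition and lower numbers for stronger inhibition:
compound 1 `Nc1ccc(NC(=O)NCCCCC(c2ccc(F)cc2)c2ccc(F)cc2)cc1` gives > 20000 nM
compound 2 `O=C(NCCCCC(c1ccc(F)cc1)c1ccc(F)cc1)Nc1cccc(C(F)(F)F)c1` gives 3380 nM
compound 3 `O=C(NCCCCC(c1ccc(F)cc1)c1ccc(F)cc1)Nc1ccc(Cl)cc1C(F)(F)F` gives > 20000 nM

Among the measured compounds shown here, compound 2 holds the only true number among the three. The value of compound 1 is a limit of this assay, not a number. The value of compound 3 is likewise a limit. Compound 4 `Cc1cc(Cl)ccc1NC(=O)NCCCCC(c1ccc(F)cc1)c1ccc(F)cc1` is not yet measured; it differs from compound 2 as follows: 4-chloro-2-methylphenyl in place of 3-(trifluoromethyl)phenyl on an amide-type nitrogen.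

For the measured compounds named here, two measured steps bear on this change. First, an at least 5.9-fold lower number from compound 1 to compound 2 (0.77 log units; beyond the scatter). Second, and closer in kind, an at least 5.9-fold higher number from compound 2 to compound 3 (0.77 log units; beyond the scatter), where the entering group carries the same 4-chloro substitution pattern that enters in compound 4. On that basis a step to higher numbers is expected, of at least modest size, with a fair chance that compound 4 only reaches (the limit of > 20000 nM in this assay, at which 2 of the 3 values shown sit). The expected step is a 3.0-fold higher number from compound 2 to compound 4 (0.47 log units; beyond the scatter). Compound 4 is therefore estimated at 10000 nM, within a range from 3000 nM to 30000 nM.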

Compound 4, half-maximal inhibitory concentration: > 20000 nM
Compound 4 ended at the assay's limit; the forecaster's own chance of this, stated with the estimate: 40%; at least 2.0-fold (0.30 log units) between middle value and limit.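

In this assay, 4-chloro-2-methylphenyl on the amide-type nitrogen gives an at least 5.9-fold higher number from compound 2 to compound 4 (0.77 log units; beyond the scatter), so among the compounds shown, a 4-chloro aryl group without trifluoromethyl, like 4-chloro-2-(trifluoromethyl)phenyl in compound 3, also fails to keep a measurable value. Compound 4 gives > 20000 nM, which is a limit and not a number. The steps from compound 3 to compound 4 and from compound 1 to compound 4 cannot be read, as both ends of each step are limits.

Going by these compounds, only compound 2 gives a true number, so any order among the other compounds stays open: the limit of > 20000 nM in this assay, at which 3 of the 4 values shown sit. Also open, on these data alone, is whether 4-chlorophenyl alone, 2-methylphenyl alone or 3-methoxyphenyl on the same nitrogen would give a number close to that of compound 2 at 3380 nM.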